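Swapping the Halogenated Phenyl in a Brominated Series

The compounds below may be only part of what the source reports. "The series", "measured", "known", "first", "only" and "open" are said of these compounds alone.

Measured compounds:
compound 1 `OC(CCn1nc2c(Br)c(Br)c(Br)c(Br)c2n1)c1cccc(Br)c1` — 11%
compound 2 `OC(CCn1nc2c(Br)c(Br)c(Br)c(Br)c2n1)c1ccccc1` — 23%

Both compounds were tested in a functional assay on MCF7 cells (Homo sapiens) for antiproliferative activity, read by MTT assay, with a stated time of 48 h, tested at 50 uM (on this read-out lower numbers stand for a stronger effect and higher numbers for a weaker effect at the one concentration tested), and compound 1 gives the lowest of the two numbers, meaning the stronger effect. For the measured compounds named here, the one measured step is a number 12 percentage points higher from compound 1 to compound 2 (beyond the scatter), which came with hydrogen in place of bromo on an aromatic carbon: taking the bromo away weakened the effect by a modest amount.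

Compound 3 `OC(CCn1nc2c(Br)c(Br)c(Br)c(Br)c2n1)c1ccc(Cl)cc1` differs from compound 1 by 4-chlorophenyl in place of 3-bromophenyl on a saturated chain carbon bound to an oxygen on a saturated carbon and a saturated chain carbon. Going by the values given here, no measured step covers a change from one halogenated phenyl to another, so the only guidance is that a phenyl without a halogen gave a weaker effect than compound 1. Since compound 3 still carries a halogen, the expected step in this assay is a number 6 percentage points higher from compound 1 to compound 3 (within the scatter), small and uncertain in direction. Compound 3 is therefore estimated at 17%, with a range from 7% to 30%.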

Compound 3, a percentage reported as activity, at one concentration (the size of the read-out at that concentration, not a potency): 9%
For compound 3 the middle estimate is 8 percentage points above the measured one, and the stated range covers the measured number.
By their numbers in this assay, from the lowest: compounds 3 and 1 (each within the scatter of the next); then compound 2.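

In this assay, 4-chlorophenyl in place of 3-bromophenyl gives a number 2 percentage points lower from compound 1 to compound 3 (within the scatter), so this assay does not separate these two halogenated phenyl groups. Chloro in place of hydrogen on an aromatic carbon gives a number 14 percentage points lower from compound 2 to compound 3 (beyond the scatter), which means that compound 1 and compound 3, the two compounds with a halogen on the phenyl ring, both differ from compound 2 in the same direction, toward a stronger effect. No measurement at hand explains this difference.

On these data alone, compound 1 and compound 3 differ in both the halogen and where it sits on the ring, so the contribution of each change remains open. Also open, as far as these compounds go, is whether a halogen is needed at all, or whether a methoxy group or an amine on the phenyl ring would give a similar number.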